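Methoxy to Hydroxy on a Second Core

This account rests on a few compounds, and the source may have more. Where it says the series, first, only, none or still open, it means among the compounds named here.

Compound 1 `COc1ccc(C(=N)SCc2ccccc2)cc1` in an ADME assay for pharmacokinetics, in phosphate buffer, with a stated time of 30 min, at pH 7.4, tested at 1 mM, at a dose of 1 mM, in the presence of a further agent that is not named here (on this read-out lower numbers stand for lower exposure and higher numbers for higher exposure at the dose given), gives 7200 nM.
Compound 3 `N=C(SCc1ccccc1)c1ccc(O)cc1` in this assay gives 6800 nM.
Compound 2 `COc1ccc(C(=S)NCc2ccccc2)cc1` in this assay gives < 300 nM, which is a limit of the assay and not a number (the limit of < 300 nM in this assay, at which 1 of the 3 values shown sits).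

Compound 1 and compound 3 differ by one change, (hydrogen in place of methyl on an oxygen on an aromatic ring), and that change made a 1.1-fold lower number from compound 1 to compound 3 (0.02 log units; within the scatter). Compound 2 and compound 1 are built from the same atoms joined differently; the difference between the two cores is not broken down here.

Compound 4 `Oc1ccc(C(=S)NCc2ccccc2)cc1` has not yet been measured. It differs from compound 2 by hydrogen in place of methyl on an oxygen on an aromatic ring, the same kind of change as from compound 1 to compound 3, and the place matches word for word. Since that change stayed within the scatter in a 1.1-fold lower number from compound 1 to compound 3 (0.02 log units; within the scatter), compound 4 is expected to sit near compound 2, with a step that the limit leaves unreadable from compound 2 to compound 4 expected. The estimate for compound 4 is 150 nM, expected between 30 nM and 600 nM.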

Compound 4, maximal plasma concentration: 1100 nM
Estimate against measurement, compound 4: 7.3-fold (0.87 log units) below; measured number outside the range, above it.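

In this assay, the change from methoxy to hydroxy did not behave alike on the two cores: the same change on two cores in this assay, a 1.1-fold lower number (0.02 log units; within the scatter) from compound 1 to compound 3 and an at least 3.6-fold higher number (0.56 log units; beyond the scatter) from compound 2 to compound 4, at least 3.8-fold (0.58 log units) apart, beyond the scatter of two such steps

Compound 2 gives < 300 nM, which is a limit of the assay and not a number. As far as these compounds go, the new step therefore reads an at least 3.6-fold higher number from compound 2 to compound 4 (0.56 log units; beyond the scatter), so its true size stays unknown, and one pair on each of two cores cannot show why the cores part or how the change would behave on a further core.

From the compounds shown here alone, what happens on each core when an ethyl group replaces the methyl on the oxygen stays open. So does the result of an amine in place of the methoxy.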